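Replacing Methyl with Bromo on the Aromatic Ring

This account rests on a few compounds, and the source may have more. Where it says the series, first, only, none or still open, it means among the compounds named here.

Of the compounds shown here, two sharing one fused core have so far been tested in a functional assay on A549 cells (Homo sapiens) for inhibition, read by sulforhodamine B assay, with a stated time of 48 h; a lower number here means a stronger inhibitor of growth, a higher number a weaker inhibitor of growth. Compound 1, `COC(=O)[C@@]1(C)CC[C@@H]2C3=C1CC[C@@H](C)[C@]3(C)Cc1c2[nH]c2ccccc12`, gives 4600 nM. Compound 2, `COC(=O)[C@@]1(C)CC[C@@H]2C3=C1CC[C@@H](C)[C@]3(C)Cc1c2[nH]c2c(C)cccc12`, carries a methyl on an aromatic carbon where compound 1 has hydrogen, and in this assay compound 2 gives 16000 nM. Going by the values given here, the only measured step is a 3.5-fold higher number from compound 1 to compound 2 (0.54 log units; beyond the scatter). Among the compounds with values here, compound 2 therefore stands at the higher of the two numbers, with compound 1 as its sole neighbour.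

Compound 3, `COC(=O)[C@@]1(C)CC[C@@H]2C3=C1CC[C@@H](C)[C@]3(C)Cc1c2[nH]c2c(Br)cccc12`, differs from compound 2 by bromo in place of methyl on an aromatic carbon. Within the data shown here, no measured step involves bromo, so the sole guidance is the step from compound 1 to compound 2, which raised the number modestly when methyl replaced hydrogen. The change from compound 2 to compound 3 swaps one group for another at the same place rather than removing it, and since compound 2 gives 16000 nM the number is expected to stay near that of compound 2, without a step beyond the scatter. The expected step is a 1.3-fold lower number from compound 2 to compound 3 (0.12 log units; within the scatter). Compound 3 is estimated at 12000 nM, within a range from 4000 nM to 40000 nM.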

Compound 3, concentration for 50% growth inhibition: 35000 nM
Beside the measured number, compound 3's estimate is 2.9-fold (0.46 log units) below it; the range from low to high includes it.
By their numbers in this assay, from the lowest: compound 1; then compound 2; then compound 3.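

In this assay, this place on the six-membered aromatic ring distinguishes between two groups that are each counted as 1 heavy atom with 0 hydrogen-bond donors and 0 hydrogen-bond acceptors: bromo in place of methyl gives a 2.2-fold higher number from compound 2 to compound 3 (0.34 log units; beyond the scatter). Bromo in place of hydrogen gives a 7.6-fold higher number from compound 1 to compound 3 (0.88 log units; beyond the scatter), so both groups shown at this place raise the number, and compound 1, with only hydrogen there, remains the strongest inhibitor of growth of the three. Nothing measured here explains why bromo and methyl differ at this place.

The compounds shown leave open whether any other group at this place, such as fluoro, methoxy or an amine, could bring the number below that of compound 1, or whether every replacement of hydrogen here raises it. They also leave open whether methyl and bromo would raise the number in the same order if placed on a different carbon of the same six-membered aromatic ring.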